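The source may report more compounds than this note shows. Statements on the series, on what has been measured and on what is new or still open speak of the compounds shown alone.

Three compounds have been measured in an assay on cells for displacement of a labelled ligand from 5-hydroxytryptamine receptor 5A (Homo sapiens), read by scintillation counting, with a stated time of 1.5 h; on this read-out higher numbers stand for weaker inhibition and lower numbers for stronger inhibition:

Compound 1 `Fc1ccc(-c2noc3c2CCNCC3)cc1` gives 1230 nM.
Compound 2 `Fc1ccc(-c2n[nH]c3c2CCNCC3)cc1` gives only a limit of the assay, > 10000 nM.
Compound 3 `Clc1ccc(-c2noc3c2CCNCC3)cc1` likewise gives only a limit of the assay, > 10000 nM.

Compound 1 and compound 3 share a core and differ in one place: chloro in place of fluoro on an aromatic carbon. This change carries an at least 8.1-fold higher number from compound 1 to compound 3 (0.91 log units; beyond the scatter), so the chloro compound is the weaker of the pair, and its value sits at the limit of > 10000 nM in this assay, at which 2 of the 3 values shown sit. How compound 2 differs from compound 1 is not broken down here; the two have different cores.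

Compound 4 `Clc1ccc(-c2n[nH]c3c2CCNCC3)cc1` is not yet measured. It stands to compound 2 as compound 3 stands to compound 1: chloro in place of fluoro on an aromatic carbon, the same change at the same place. Among the compounds with values here, compound 2 already sits at the limit of this assay, and in the one measured instance of this change the number rose. Compound 4 is therefore expected to stay at or beyond the limit, with a step that the limit leaves unreadable from compound 2 to compound 4 from compound 2, and the estimate for compound 4 in this assay is 30000 nM, between 10000 nM and 100000 nM.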

Compound 4, inhibition constant: > 10000 nM
Compound 4: only a limit was reported (the forecaster's own chance of this, stated with the estimate: 90%); the middle value is on the limit's open side.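

In this assay compound 4 gives only a limit of the assay, > 10000 nM. Within the data shown here, compound 2 also gives only a limit, so no step between compound 2 and compound 4 can be read: the limit of > 10000 nM in this assay, at which 3 of the 4 values shown sit.

The compounds shown leave open how chloro in place of fluoro acts on the core shared by compound 2 and compound 4.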